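Nitro in place of (dimethylamino)methyl: compound 1 to compound 4

This account rests on a few compounds, and the source may have more. Where it says the series, first, only, none or still open, it means among the compounds named here.

Measured in a functional assay on QG-56 cells (Homo sapiens) for antiproliferative activity; a higher number here means a weaker inhibitor, a lower number a stronger inhibitor:
compound 1 `COc1cccc(-c2cc(CN(C)C)cc3cc(C(O)(c4ccc(C#N)cc4)c4cncn4C)oc23)c1`: 142 nM
compound 2 `COc1ccc(C(O)(c2cc3cc([N+](=O)[O-])cc(-c4ccccc4)c3o2)c2cncn2C)cc1`: 4970 nM
compound 3 `Cn1cncc1[C@](N)(c1ccc(C#N)cc1)c1cc2cc([N+](=O)[O-])cc(-c3ccccc3)c2o1`: 206 nM

Compound 1 gives the lowest number of the three; compound 3 lies within the scatter of it, while compound 2 lies well beyond it. Compound 4 `COc1cccc(-c2cc([N+](=O)[O-])cc3cc(C(O)(c4ccc(C#N)cc4)c4cncn4C)oc23)c1` has not been measured. It differs from compound 1 in one place: nitro in place of (dimethylamino)methyl on an aromatic carbon. Among the measured compounds shown here, no step between measured compounds isolates this change. Compound 3 also carries a nitro group and a 4-cyanophenyl group, and its value 206 nM sits within the scatter of compound 1, whereas compound 2 differs from compound 4 in more than the nitro group. The step of a 1.8-fold higher number from compound 1 to compound 4 (0.25 log units; within the scatter) is expected to remain within the scatter. Compound 4 is estimated at 250 nM in this assay, with a range from 80 nM to 800 nM.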

Compound 4, half-maximal inhibitory concentration: 38.8 nM
Compound 4: middle estimate off by 6.4-fold (0.81 log units), on the high side; measured number outside the range, below it.
By their numbers in this assay, from the lowest: compound 4; then compounds 1 and 3 (each within the scatter of the next); then compound 2.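

In this assay, among the compounds shown here, nitro in place of (dimethylamino)methyl on this aromatic carbon gives a 3.7-fold lower number from compound 1 to compound 4 (0.56 log units; beyond the scatter) and is the first reading of this position with the rest of compound 1 held constant. The (dimethylamino)methyl group is therefore not required here, and the step is modest but beyond the scatter. Nothing available accounts for the step.

Going by these compounds, whether the step reflects nitro entering or (dimethylamino)methyl leaving remains open, as only these two groups have been compared at this position. A carboxylic acid or a plain hydrogen there would help separate the two readings.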